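The source may report more compounds than this note shows. Statements on the series, on what has been measured and on what is new or still open speak of the compounds shown alone.

Three compounds share one core and differ only in the aryl group attached to it. Compound 1 `COc1cc(-n2cnc3ccc(-c4ccc([N+](=O)[O-])cc4)cc32)cc(OC)c1OC` gives 79 nM in a functional assay on SGC-7901 cells (Homo sapiens) for antiproliferative activity, read by MTT assay, with a stated time of 72 h; on this read-out higher numbers stand for weaker inhibition and lower numbers for stronger inhibition. Compound 2 `COc1cc(-n2cnc3ccc(-c4ccc(Cl)cc4)cc32)cc(OC)c1OC` gives 1270 nM, and compound 3 `COc1ccccc1-c1ccc2ncn(-c3cc(OC)c(OC)c(OC)c3)c2c1` gives 5050 nM, the highest of the three numbers; the nearest step to it is a 4.0-fold higher number from compound 2 to compound 3 (0.60 log units; beyond the scatter) and the furthest is a 64-fold higher number from compound 1 to compound 3 (1.81 log units; beyond the scatter). Compound 4 `COc1cc(-n2cnc3ccc(-c4ccc(O)cc4)cc32)cc(OC)c1OC` is not yet measured. Its change from compound 3 is 4-hydroxyphenyl in place of 2-methoxyphenyl on an aromatic carbon. Both steps reaching compound 3 bear on this change, since each puts 2-methoxyphenyl in place of 4-chlorophenyl or 4-nitrophenyl and both raise the number, one modestly and one largely. For the measured compounds named here, a 4-hydroxyphenyl has no precedent here, so a lower number for compound 4 is expected, by a 3.4-fold lower number from compound 3 to compound 4 (0.53 log units; beyond the scatter). Compound 4 is estimated at 1500 nM, within 400 nM to 6000 nM.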

Compound 4, half-maximal inhibitory concentration: > 10000 nM
Compound 4 ended at the assay's limit (the forecaster's own chance of this, stated with the estimate: 5%); middle value at least 6.6-fold (0.82 log units) away from the limit.
By their numbers in this assay, from the lowest: compound 1; then compound 2; then compound 3. At a limit, above all of these: compound 4.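

Compound 4 stands at a limit of this assay, > 10000 nM, and not at a number. Hydroxy on the phenyl group gives an at least 7.8-fold higher number from compound 2 to compound 4 (0.89 log units; beyond the scatter) and an at least 120-fold higher number from compound 1 to compound 4 (2.10 log units; beyond the scatter), so this single change on the aryl group moves the read-out in the weak direction beyond what chloro showed, and further still against nitro. Against compound 3 the result is an at least 1.9-fold higher number from compound 3 to compound 4 (0.29 log units; that floor lies within the scatter), so 4-hydroxyphenyl and 2-methoxyphenyl cannot be put in order.

Going by these compounds, whether an amine or a carboxylic acid in place of the hydroxy would sit nearer compound 1 or compound 4 remains open.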